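This account rests on a few compounds, and the source may have more. Where it says the series, first, only, none or still open, it means among the compounds named here.

Values in an ADME assay on microsomes from liver (Homo sapiens) for metabolic stability, read by HPLC, with a stated time of 60 min, tested at 0.2 mg/mL (on this read-out higher numbers stand for fast clearance and lower numbers for slow clearance), so far:
- compound 1 `O=C(NCc1ccc(Cl)cc1Cl)[C@@H]1CCC(=O)N1c1cccs1` gives 1070 mL.min-1.g-1
- compound 2 `O=C(NCc1ccc(Cl)cc1Cl)[C@@H]1CCC(=O)N1c1ccsc1` gives 762 mL.min-1.g-1
- compound 3 `O=C(NCc1ccc(Cl)cc1Cl)[C@@H]1CCC(=O)N1c1ccco1` gives 411 mL.min-1.g-1

Compound 3 sits clearly under compound 1 (a 2.6-fold lower number from compound 1 to compound 3 (0.42 log units; beyond the scatter)) but is not separated from compound 2 (a 1.9-fold lower number from compound 2 to compound 3 (0.27 log units; within the scatter)).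

The next compound is compound 4 `O=C(NCc1ccc(Cl)cc1Cl)[C@@H]1CCC(=O)N1c1ccoc1`, with furan-3-yl in place of furan-2-yl on an amide-type nitrogen in a ring.

Among the compounds with values here, the closest precedent is the matching change in the thiophene pair, thiophen-3-yl in place of thiophen-2-yl (a 1.4-fold lower number from compound 1 to compound 2 (0.15 log units; within the scatter)). Within the data shown here, it is the only measured step of this kind, so the basis is thin. The two steps to the furan-2-yl compound exchange the ring itself and bear on this change less directly.

No step beyond the scatter is therefore expected in this assay, with a slight lean towards lower numbers. The expected change is a 1.2-fold lower number from compound 3 to compound 4 (0.07 log units; within the scatter) on this estimate. Compound 4 is estimated at 350 mL.min-1.g-1 and is expected to fall between 180 mL.min-1.g-1 and 680 mL.min-1.g-1 in this range.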

Compound 4, intrinsic clearance in microsomes: 630 mL.min-1.g-1
Compound 4: the middle estimate sits 1.8-fold (0.26 log units) below what was measured; the range from low to high includes it.
By their numbers in this assay, from the lowest: compounds 3, 4, 2 and 1 (each within the scatter of the next, the first and the last beyond it).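

The exchange of furan-2-yl for furan-3-yl on an amide-type nitrogen in a ring gives (a 1.5-fold higher number from compound 3 to compound 4 (0.19 log units; within the scatter)) in this assay, so in the furan pair, as in the thiophene pair (a 1.4-fold lower number from compound 1 to compound 2 (0.15 log units; within the scatter)), the point of attachment does not separate the two compounds. Within the data shown here, compound 4 also stays within the scatter of both thiophenes (a 1.2-fold lower number from compound 2 to compound 4 (0.08 log units; within the scatter); a 1.7-fold lower number from compound 1 to compound 4 (0.23 log units; within the scatter)), so furan in place of thiophene does not by itself give a separated pair, and the one such pair here, compound 1 and compound 3, holds only for those two attachments. Nothing measured in this series accounts for these values.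

From the compounds shown here alone, all four groups are five-membered aromatic rings with one hetero atom, so the response to a phenyl, a pyridyl or a thiazolyl group on that nitrogen remains open. Also open, going by these compounds, is what a methyl group or a chlorine on the furan-3-yl ring would do to the clearance number.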